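This account rests on a few compounds, and the source may have more. Where it says the series, first, only, none or still open, it means among the compounds named here.

Measured in a physicochemical assay for lipophilicity; on this read-out higher numbers stand for higher lipophilicity and lower numbers for lower lipophilicity:
compound 1 `C[n+]1ccn(CCC#N)c1/C=N/O` gives -3.3
compound 2 `C[n+]1ccn(COCCCCCl)c1/C=N/O` gives -1.47

Compound 2 stands at the higher of the two values in this assay, well clear of compound 1. Compound 3 `C[n+]1ccn(COCC(C)(C)[N+](=O)[O-])c1/C=N/O` differs from compound 2 in one place: 1-methyl-1-nitroethyl in place of 3-chloropropyl on a saturated chain carbon bound to an oxygen on a saturated carbon. For the measured compounds named here, no step between measured compounds covers such a change, so the estimate rests on the two values alone. A downward step of moderate size is expected, a number 0.93 log units lower from compound 2 to compound 3 (beyond the scatter), beyond the scatter. Compound 3 is estimated at -2.4, with a range from -3.2 to -1.6.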

Compound 3, distribution coefficient: -1.96
The estimate for compound 3 lay 0.44 log units below the measured number, and the stated range covers the measured number.
By their numbers in this assay, from the lowest: compound 1; then compound 3; then compound 2.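

On a saturated chain carbon bound to an oxygen on a saturated carbon, 1-methyl-1-nitroethyl in place of 3-chloropropyl gives a modest change in this assay with a number 0.49 log units lower from compound 2 to compound 3 (beyond the scatter). The entering group has hydrogen-bond acceptors and the leaving group has none, yet this single pair cannot tie the step to that difference. No supporting data bear on the origin of the step.

Still open, as far as these compounds go, is how a carboxylic acid, an amine or a longer chain at this place would stand in this assay. The separate contributions of the chlorine and the nitro group also remain unresolved.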